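The source may hold more compounds than are shown below. What is called first, only, known or untested is meant among the compounds shown, and "the series" means these compounds.

Measured in a functional assay on the whole organism with Rattus norvegicus as the target; on this read-out higher numbers stand for an effect only at larger amounts of compound and lower numbers for an effect already at smaller amounts:
- Compound 1 `COC(=O)CC/C=C\CC[C@H]1C(=O)C[C@@H](O)[C@@H]1/C=C/CC(C)(O)CCC1CCCC1`: 1.31 mg/kg
- Compound 2 `COC(=O)CC/C=C\CC[C@H]1C(=O)C[C@@H](O)[C@@H]1/C=C/C[C@@](C)(O)C#CC1=CCCC1`: > 3.16 mg/kg, a limit and not a number
- Compound 3 `COC(=O)CC/C=C\CC[C@H]1C(=O)C[C@@H](O)[C@@H]1/C=C/CC(C)(O)CCC1CCC1`: 0.316 mg/kg

Compound 3 stands lowest in this assay at 0.316 mg/kg, with compound 1 the nearest.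

The next structure is compound 4 `COC(=O)CC/C=C\CC[C@H]1C(=O)C[C@@H](O)[C@@H]1/C=C/C[C@@](C)(O)/C=C/C1CCCC1`, and its difference from compound 3 is 3-cyclopentyl-1-hydroxy-1-methylprop-2-en-1-yl in place of 3-cyclobutyl-1-hydroxy-1-methylpropyl on a saturated chain carbon bound to a double-bonded chain carbon. The ring change is the reverse of the one measured in a 4.1-fold lower number from compound 1 to compound 3 (0.62 log units; beyond the scatter), so that step suggests a rise in the number. The other relevant step is an at least 2.4-fold higher number from compound 1 to compound 2 (0.38 log units; beyond the scatter), which also points upward. It is only a partial guide, as it brings a triple bond and a ring double bond, whereas the group in compound 4 has a single double bond outside aromatic rings and a saturated ring. A modest rise in this assay is therefore expected, close in size to the ring step. The estimate is a 3.8-fold higher number from compound 3 to compound 4 (0.58 log units; beyond the scatter). For compound 4 the expected value is 1.2 mg/kg, with an estimated range from 0.3 mg/kg to 4.5 mg/kg.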

Compound 4, dose for half-maximal effect: 1.95 mg/kg
The estimate for compound 4 lay 1.6-fold (0.21 log units) below the measured number; the range from low to high includes it.
By their numbers in this assay, from the lowest: compound 3; then compounds 1 and 4 (each within the scatter of the next). At a limit, above all of these: compound 2.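

In this assay, adding the double bond while keeping the cyclopentyl ring gives a 1.5-fold higher number from compound 1 to compound 4 (0.17 log units; within the scatter), so this change at the saturated chain carbon bound to a double-bonded chain carbon shows no readable effect on its own. The change that also replaces cyclobutyl with cyclopentyl gives a 6.2-fold higher number from compound 3 to compound 4 (0.79 log units; beyond the scatter), which runs in the same direction as the reverse of a 4.1-fold lower number from compound 1 to compound 3 (0.62 log units; beyond the scatter) and places the clear difference with the ring change rather than the double bond. Compound 2 carries a limit and not a number, so an at least 1.6-fold lower number from compound 2 to compound 4 (0.20 log units; that floor lies within the scatter) gives only a floor: the limit of > 3.16 mg/kg in this assay, at which 1 of the 4 values shown sits.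

On these data alone, it remains open whether the cyclobutyl ring keeps its lower number alongside the double bond, and how a cyclohexyl or phenyl ring would read at this chain end. As far as these compounds go, how a carboxylic acid in place of the methyl ester would read in this assay also remains open.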